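This account rests on a few compounds, and the source may have more. Where it says the series, first, only, none or still open, it means among the compounds named here.

Measured compounds:
Compound 1 `CC(C)=CCc1cc(C(=O)Nc2cc3ccc(OCC4CCCN(C)C4)c(C)c3oc2=O)ccc1O` gives 2640 nM in a functional assay on MCF7 cells (Homo sapiens) for antiproliferative activity; on this read-out higher numbers stand for weaker inhibition and lower numbers for stronger inhibition.
Compound 2 `CCN(CC)CCCOc1ccc2cc(NC(=O)c3ccc(O)c(CC=C(C)C)c3)c(=O)oc2c1C` gives 6390 nM.
Compound 3 `CCCN(CCC)CCCOc1ccc2cc(NC(=O)c3ccc(O)c(CC=C(C)C)c3)c(=O)oc2c1C` gives only a limit of the assay, > 50000 nM.

Among the two values that are numbers, compound 1 has the lower one, with compound 2 nearest: a 2.4-fold higher number from compound 1 to compound 2 (0.38 log units; beyond the scatter). The value of compound 3 is a limit and not a number, and one of the three results sits at it (the limit of > 50000 nM in this assay, at which 1 of the 3 values shown sits).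

Compound 4 `CC(C)=CCc1cc(C(=O)Nc2cc3ccc(OCCCNC(C)C)c(C)c3oc2=O)ccc1O` differs from compound 1 in one place: 2-(isopropylamino)ethyl in place of 1-methylpiperidin-3-yl on a saturated chain carbon bound to an oxygen on an aromatic ring.

Going by the values given here, three measured steps bear on this change, all of them replacing or enlarging the amine-bearing group on the same oxygen. Opening the ring gave a 2.4-fold higher number from compound 1 to compound 2 (0.38 log units; beyond the scatter). Opening it with the larger dipropylamino gave an at least 18-fold higher number from compound 1 to compound 3 (1.27 log units; beyond the scatter), and going from diethylamino to dipropylamino gave an at least 7.8-fold higher number from compound 2 to compound 3 (0.89 log units; beyond the scatter). Every step that left the ring weakened inhibition, and the larger the open-chain amine, the weaker it became. Compound 4 also leaves the ring, but its isopropylamino group is smaller than the diethylamino of compound 2, so a modest rise is expected, similar to the step to compound 2 or a little less: a 1.7-fold higher number from compound 1 to compound 4 (0.23 log units; within the scatter). Compound 4 is therefore estimated at 4500 nM, with a likely range from 1800 nM to 12000 nM.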

Compound 4, half-maximal inhibitory concentration: 740 nM
The estimate for compound 4 lay 6.1-fold (0.78 log units) above the measured number, outside the stated range (below it).
By their numbers in this assay, from the lowest: compound 4; then compound 1; then compound 2. At a limit, above all of these: compound 3.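

In this assay, leaving the ring need not cost inhibition, as a 3.6-fold lower number from compound 1 to compound 4 (0.55 log units; beyond the scatter) shows: compound 4 goes against the earlier pattern, which compounds 2 and 3 still follow. Among the open-chain amines, the group at the end of the chain makes a clear difference, with an 8.6-fold lower number from compound 2 to compound 4 (0.94 log units; beyond the scatter) and an at least 67-fold lower number from compound 3 to compound 4 (1.82 log units; beyond the scatter), so isopropylamino stands apart from both diethylamino and dipropylamino. The value of compound 3 is a limit of the assay and not a number: the limit of > 50000 nM in this assay, at which 1 of the 4 values shown sits.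

The compounds shown cannot separate the shape of the isopropyl group from the hydrogen-bond donor that 2-(isopropylamino)ethyl counts and 1-methylpiperidin-3-yl does not, and a tert-butylamino, cyclopropylamino or unsubstituted primary amine on the same chain would bear on that question. They also leave open how much the length of the chain matters, which a 2-(isopropylamino)ethoxy or 4-(isopropylamino)butoxy group in place of the 3-(isopropylamino)propoxy of compound 4 would test.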